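Dichlorination of the benzyl arm: expected cytotoxicity

The source may report more compounds than this note shows. Statements on the series, on what has been measured and on what is new or still open speak of the compounds shown alone.

Measured so far:
compound 1, `Cn1cc(SCc2nnc(SCc3ccccc3)n2-c2c(Cl)cccc2Cl)c2ccccc21`, in a toxicity assay on HEK-293T cells (Homo sapiens) for cytotoxicity, read by CCK-8 assay, with a stated time of 48 h; on this read-out higher numbers stand for lower toxicity in this test and lower numbers for higher toxicity in this test: > 100000 nM
compound 2, `Cn1cc(SCc2nnc(SCc3ccccc3OC(F)(F)F)n2-c2c(Cl)cccc2Cl)c2ccccc21`, in this assay: > 100000 nM

Compound 1 stands at > 100000 nM in this assay, and this value is a limit of the assay, not a number. Compound 2 likewise gives > 100000 nM in this assay, again a limit. Going by the values given here, the only measured step, a step that the two limits leave unreadable from compound 1 to compound 2, is thus of unreadable size, and the whole evidence is the limit of > 100000 nM in this assay, at which 2 of the 2 values shown sit. Compound 3, `Cn1cc(SCc2nnc(SCc3cccc(Cl)c3Cl)n2-c2c(Cl)cccc2Cl)c2ccccc21`, differs from compound 1 by 2,3-dichlorophenyl in place of phenyl on a saturated chain carbon bound to a sulfur. The step from compound 1 to compound 2 is the one that bears on it, since it also alters the same phenyl group, and it showed no readable movement away from the limit. No step beyond the scatter is expected in this assay, and compound 3 is estimated to remain at the limit, meaning a step that the limit leaves unreadable from compound 1 to compound 3. The estimate for compound 3 is 150000 nM, with a range from 60000 nM to 400000 nM.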

Compound 3, half-maximal cytotoxic concentration: > 100000 nM
Compound 3 gave a limit, no number (the forecaster's own chance of this, stated with the estimate: 85%); the middle value is on the limit's open side.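

Compound 3 gives > 100000 nM in this assay, which is a limit and not a number. The steps to compound 3 from compound 1 and from compound 2 therefore cannot be read, and the whole series rests on one limit: the limit of > 100000 nM in this assay, at which 3 of the 3 values shown sit.

The compounds shown leave open where each true value lies beyond that limit, and so whether these changes to the phenyl group alter toxicity at all.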